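The source may hold more compounds than are shown below. What is called first, only, known or untested is meant among the compounds shown, and "the series" means these compounds.

Compound 1, `COc1cc(N)c(Cl)cc1C(=O)NC1CCNCC1`, gives 398 nM in a functional assay on HEK293 cells for agonist activity at 5-hydroxytryptamine receptor 4 (Homo sapiens), read by cAMP accumulation; a higher number here means that more compound is needed for the effect, a lower number that less compound is needed. Compound 2, `COc1cc(N)c(Cl)cc1C(=O)NC1CCN(CCCCCO)CC1`, carries 5-hydroxypentyl in place of hydrogen on an amine nitrogen in a ring, and in this assay compound 2 gives 15.9 nM. The step from compound 1 to compound 2 is large: a 25-fold lower number from compound 1 to compound 2 (1.40 log units; beyond the scatter). Among the two numbers measured, compound 2 stands at the lower one, with compound 1 as its only neighbour.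

Compound 3, `COc1cc(N)c(Cl)cc1C(=O)NC1CCN(CCCCCCCCN2CCCCC2)CC1`, is reached from compound 2 by 3-(piperidin-1-yl)propyl in place of hydroxy on a saturated chain carbon, five bonds along the chain from an amine nitrogen in a ring. Within the data shown here, the chain on the ring nitrogen, whose introduction gave the step from compound 1 to compound 2, is kept and extended; the single measured step therefore shows only that such a chain is favourable, and no measured pair speaks to exchanging the terminal hydroxy for a piperidine-bearing tail. No step beyond the scatter is expected in this assay, and compound 3 is estimated at 10 nM, between 2 nM and 50 nM, which amounts to an expected 1.6-fold lower number from compound 2 to compound 3 (0.20 log units; within the scatter).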

Compound 3, half-maximal effective concentration: 3.16 nM
Compound 3: the middle estimate sits 3.2-fold (0.50 log units) above what was measured; measured number inside the range.
By their numbers in this assay, from the lowest: compound 3; then compound 2; then compound 1.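

Exchanging hydroxy for 3-(piperidin-1-yl)propyl, on a saturated chain carbon, five bonds along the chain from an amine nitrogen in a ring, gives in this assay a 5.0-fold lower number from compound 2 to compound 3 (0.70 log units; beyond the scatter), a modest step but one beyond the scatter. The earlier step showed only that a chain on the ring nitrogen lowers the number; this one shows that the terminal hydroxy is not needed to keep that gain, and that the number can fall further when the chain is extended and ends in a six-membered non-aromatic ring. Nothing measured on these compounds says why the number falls.

This single step changes the chain length and the terminal group together, so the compounds shown do not separate the two: a longer chain still ending in hydroxy, or a piperidine placed directly on the pentyl chain, could account for part or all of it. Also open, going by these compounds, are other chain ends, such as a morpholine, a dimethylamine or a carboxylic acid, and whether a still longer chain would lower the number further.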